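Thiophene carboxylic acid amides: MT4 cytotoxicity notes

A few compounds are considered here, and "the series" means these few. Any claim that something is new, unique, unknown or untested is made for them only; others in the source may bear on it.

Compound 1 `CC1CC=C(C(=O)N(c2cc(C#CC(C)(C)C)sc2C(=O)O)C(C)C)CC1` gives > 20000 nM in an ADME assay on MT4 cells (Homo sapiens) for cytotoxicity, with a stated time of 5 days; on this read-out higher numbers stand for lower toxicity in this test and lower numbers for higher toxicity in this test.
Compound 2 `CC(C)N(C(=O)[C@@H]1CC[C@@H]2C[C@@H]2CC1)c1cc(C#CC(C)(C)C)sc1C(=O)O` gives > 20000 nM in this assay.
Compound 3 `CC(C)N(c1cc(C#CC(C)(C)C)sc1C(=O)O)C(=O)[C@H]1CC[C@H](CF)CC1` gives > 20000 nM in this assay.

Each of these three values is a limit of the test, not a number; they all sit at the limit of > 20000 nM in this assay, at which 3 of the 3 values shown sit. Compound 3 therefore stands only at a limit, and the two other compounds stand at the same limit. The steps among the measured compounds, a step that the two limits leave unreadable from compound 1 to compound 2, a step that the two limits leave unreadable from compound 1 to compound 3 and a step that the two limits leave unreadable from compound 2 to compound 3, cannot be read for size because both ends of each are limits.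

Compound 4 `CC(C)N(C(=O)C1CCCCC1)c1cc(C#CC(C)(C)C)sc1C(=O)O` is not yet measured. It differs from compound 3 by hydrogen in place of fluoromethyl on a saturated ring carbon. Within the data shown here, the steps from compound 1 to compound 3 and from compound 2 to compound 3 concern the same 4-(fluoromethyl)cyclohexyl group, but give no readable size; no measured step shows a direction. With every neighbour at the limit, no step beyond the scatter is expected, and the step that the limit leaves unreadable from compound 3 to compound 4 is expected to stay unreadable in the same way. Compound 4 is expected to give 30000 nM in this assay, with a range from 15000 nM to 100000 nM, most likely reported again only as a limit.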

Compound 4, half-maximal cytotoxic concentration: > 20000 nM
Compound 4 ended at the assay's limit; the forecaster's own chance of this, stated with the estimate: 85%; the middle value is on the limit's open side.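

No step among compound 1, compound 2, compound 3 and compound 4 can be read for size, because both ends of each step are limits of the test: the limit of > 20000 nM in this assay, at which 4 of the 4 values shown sit.

Still open, from the compounds shown here alone, is where the true values of these four compounds lie, and whether any group on the carbonyl carbon brings a measurable value in this assay.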